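Aryl Exchange on the Shared Core: Expecting Compound 3

The source may hold more compounds than are shown below. What is called first, only, known or untested is meant among the compounds shown, and "the series" means these compounds.

compound 1 `O=Cc1ccc(-c2cn3ccnc3c(-c3ccc4ncn(C5CCCCC5)c4c3)n2)cc1` — 19%
compound 2 `Brc1ccc(-c2cn3ccnc3c(-c3ccc4ncn(C5CCCCC5)c4c3)n2)cc1` — 42.4%

In a functional assay on PC-3 cells (Homo sapiens) for inhibition, read by sulforhodamine B assay, with a stated time of 48 h, tested at 10 uM (on this read-out lower numbers stand for less inhibition and higher numbers for more inhibition at the one concentration tested (going by the name of the read-out)), compound 1 gives 19%. In this assay compound 2 gives 42.4%. Compound 2 therefore stands highest of the two numbers, and its nearest neighbour is compound 1, reached by the step of a number 23.4 percentage points higher from compound 1 to compound 2 (beyond the scatter). Compound 3 `FC(F)(F)c1cccc(-c2cn3ccnc3c(-c3ccc4ncn(C5CCCCC5)c4c3)n2)c1` is not yet measured; it differs from compound 2 in one place: 3-(trifluoromethyl)phenyl in place of 4-bromophenyl on an aromatic carbon. For the measured compounds named here, the only measured step, bromo in place of formyl, concerns a different change at the same aromatic carbon and so bears only loosely on this one; no step swaps the whole aryl group. Lacking a direct precedent, compound 3 is expected to move by a number 2.4 percentage points lower from compound 2 to compound 3 (within the scatter), a step not beyond the scatter. Compound 3 is estimated at 40%, within a range from 20% to 60%.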

Compound 3, a percentage reported as inhibition, at one concentration (the size of the read-out at that concentration, not a potency): 36.5%
The estimate for compound 3 lay 3.5 percentage points above the measured number; the range from low to high includes it.
By their numbers in this assay, from the lowest: compound 1; then compounds 3 and 2 (each within the scatter of the next).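

In this assay the exchange of 4-bromophenyl for 3-(trifluoromethyl)phenyl on this aromatic carbon shows as a number 5.9 percentage points lower from compound 2 to compound 3 (within the scatter), so the two aryl groups cannot be told apart by this read-out even though the whole group was replaced. The same 3-(trifluoromethyl)phenyl group, set against the 4-formylphenyl group, gives a number 17.5 percentage points higher from compound 1 to compound 3 (beyond the scatter), which leaves compound 1 apart from compound 3 as it already stood apart from compound 2. Nothing at hand gives a reason for these numbers.

The compounds shown leave open whether the kind of substituent and its place on the phenyl ring matter separately, since both differ in this exchange. They also leave open how this position would respond to a phenyl group carrying an amine or a carboxylic acid.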